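This account rests on a few compounds, and the source may have more. Where it says the series, first, only, none or still open, it means among the compounds named here.

Compound 2 `Clc1ccc(-c2cn3ccnc3c(-c3ccc4ncn(C5CCCCC5)c4c3)n2)cc1` and compound 1 `Fc1ccc(-c2cn3ccnc3c(-c3ccc4ncn(C5CCCCC5)c4c3)n2)cc1` share one core and differ only in the group attached to the aromatic carbon of the shared core. In a functional assay on SN12C cells (Homo sapiens) for inhibition, read by sulforhodamine B assay, with a stated time of 48 h, tested at 10 uM (on this read-out lower numbers stand for less inhibition and higher numbers for more inhibition at the one concentration tested (going by the name of the read-out)), compound 1 gives 3.97%. In this assay compound 2 gives 13.5%. Among the compounds with values here, of the two numbers measured so far, compound 2 stands at the top, yet the step of a number 9.5 percentage points higher from compound 1 to compound 2 (within the scatter) lies within the scatter, so the two numbers must be taken as level. Compound 3 `FC(F)(F)c1cccc(-c2cn3ccnc3c(-c3ccc4ncn(C5CCCCC5)c4c3)n2)c1` has not yet been measured; it carries 3-(trifluoromethyl)phenyl in place of 4-chlorophenyl on an aromatic carbon. Within the data shown here, the only measured step, a number 9.5 percentage points higher from compound 1 to compound 2 (within the scatter), bears on this change in that it also swaps the group on the same aromatic carbon, and it stayed within the scatter. On that basis compound 3 is expected to show no step beyond the scatter, a number 1.5 percentage points lower from compound 2 to compound 3 (within the scatter). Compound 3 is estimated at 12% in this assay, within a range from 0% to 28%.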

Compound 3, a percentage reported as inhibition, at one concentration (the size of the read-out at that concentration, not a potency): 8.3%
The estimate for compound 3 lay 3.7 percentage points above the measured number, and the stated range covers the measured number.
By their numbers in this assay, from the lowest: compounds 1, 3 and 2 (each within the scatter of the next).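

In this assay, 3-(trifluoromethyl)phenyl in place of 4-chlorophenyl gives a number 5.2 percentage points lower from compound 2 to compound 3 (within the scatter) and in place of 4-fluorophenyl gives a number 4.3 percentage points higher from compound 1 to compound 3 (within the scatter) on the same aromatic carbon of the shared core. The earlier compounds shown here showed only one halogen exchanged for another, whereas this change also brings a different substituent at a different place on the phenyl ring, with 10 heavy atoms instead of 7, and the three compounds still stand level. No measurement is available that would explain this result.

All three groups are phenyl rings carrying fluorine or chlorine. As far as these compounds go, whether a phenyl ring bearing an amine or a carboxylic acid, or a longer alkyl chain in place of the ring, would move the number beyond the scatter remains open.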